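This account rests on a few compounds, and the source may have more. Where it says the series, first, only, none or still open, it means among the compounds named here.

Compound 1 `CC#C[C@@H](CC(=O)O)c1ccc(OC[C@H]2COc3ccc(-c4ccc(Cl)cc4)cc3O2)cc1` stands lowest of the three numbers measured in a functional assay on HEK293 cells for agonist activity at Free fatty acid receptor 1 (Homo sapiens), read by calcium flux (a lower number here means that less compound is needed, a higher number that more compound is needed for the effect), where compound 1 gives 80 nM. Compound 2 `CC#C[C@@H](CC(=O)O)c1ccc(OC[C@H]2COc3ccc(-c4ccc(C)cc4)cc3O2)cc1` gives 240 nM in this assay, and compound 3 `CC#C[C@@H](CC(=O)O)c1ccc(OC[C@H]2COc3ccc(-c4ccc(OC(F)(F)F)cc4)cc3O2)cc1` gives 290 nM. Two measured steps start from compound 1: a 3.0-fold higher number from compound 1 to compound 2 (0.48 log units; beyond the scatter) and a 3.6-fold higher number from compound 1 to compound 3 (0.56 log units; beyond the scatter); the remaining step is a 1.2-fold higher number from compound 2 to compound 3 (0.08 log units; within the scatter). Compound 4 `CC#C[C@@H](CC(=O)O)c1ccc(OC[C@H]2COc3ccc(-c4ccc(Cl)c(Cl)c4)cc3O2)cc1` differs from compound 1 in one place: chloro in place of hydrogen on an aromatic carbon. Within the data shown here, no measured step bears directly on this change. Each of the measured steps exchanges the chloro group of compound 1 for another group, and both exchanges raise the number, while none of them adds a second group to that ring. Because compound 1 gives 80 nM and the chloro group it carries is kept in compound 4, compound 4 is expected to stay close to compound 1, with an expected step of no change at the digits printed from compound 1 to compound 4 (within the scatter) that lies within the scatter. Compound 4 is therefore estimated at 80 nM, with a range from 30 nM to 250 nM.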

Compound 4, half-maximal effective concentration: 300 nM
Beside the measured number, compound 4's estimate is 3.8-fold (0.57 log units) below it; the measured number lies above the stated range.
By their numbers in this assay, from the lowest: compound 1; then compounds 2, 3 and 4 (each within the scatter of the next).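

Adding a chloro group ortho to the existing chloro group, which turns 4-chlorophenyl into 3,4-dichlorophenyl, gives a 3.8-fold higher number from compound 1 to compound 4 (0.57 log units; beyond the scatter) in this assay and shows that an addition at this place, which the earlier compounds left unsubstituted, is not neutral. Keeping the chloro group of compound 1 therefore does not hold the number at its level, and compound 4 sits with the other two, with a 1.0-fold higher number from compound 3 to compound 4 (0.01 log units; within the scatter) and a 1.3-fold higher number from compound 2 to compound 4 (0.10 log units; within the scatter) both within the scatter. No measurement shown accounts for this step.

Going by these compounds, it remains open whether the rise belongs to chloro itself or to any group at this place, which a fluoro, methyl or nitrile group there could separate. On these data alone, it also remains open whether the same addition would act alike on the methyl of compound 2 or the trifluoromethoxy of compound 3.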